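Replacing a Linking Amino Group: An Estimate for Compound 3

The source may hold more compounds than are shown below. What is called first, only, known or untested is meant among the compounds shown, and "the series" means these compounds.

Compound 1 `COc1cc(Cl)cc(-c2nn(-c3cccc(NC(=O)Nc4ccc(Cl)c(C(F)(F)F)c4)c3)cc2-c2ccncc2)c1`: 19.2%
Compound 2 `COc1cc(Cl)cc(-c2nn(-c3cccc(NC(=O)Nc4cccc(C(F)(F)F)c4)c3)cc2-c2ccncc2)c1`: 34.1%

In a functional assay on OVCAR-5 cells (Homo sapiens) for inhibition, read by sulforhodamine B assay, with a stated time of 48 h, tested at 10 uM (a lower number here means a stronger effect, a higher number a weaker effect of the compound at the concentration tested), compound 1 gives 19.2%. Compound 2 gives 34.1%. Among the measured compounds shown here, compound 2 therefore stands highest of the two numbers, meaning the weaker effect of the pair, and the only measured step, a number 14.9 percentage points higher from compound 1 to compound 2 (beyond the scatter), separates it from compound 1.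

Compound 3 `COc1cc(Cl)cc(-c2nn(-c3cccc(NC(=O)c4cccc(C(F)(F)F)c4)c3)cc2-c2ccncc2)c1` differs from compound 2 by 3-(trifluoromethyl)phenyl in place of (3-(trifluoromethyl)phenyl)amino on a carbonyl carbon. For the measured compounds named here, the single measured step concerns a chloro group on an aromatic carbon and says nothing about the carbonyl linkage, so no measured step bears on this change. The direction and size of the step in this assay are therefore open. Compound 3 is expected to give about 38%, within a wide range from 15% to 70%. This estimate corresponds to an expected step of a number 3.9 percentage points higher from compound 2 to compound 3 (within the scatter), that is, no clear move beyond the scatter.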

Compound 3, a percentage reported as activity, at one concentration (the size of the read-out at that concentration, not a potency): 84.1%
Estimate against measurement, compound 3: 46.1 percentage points below, outside the stated range (above it).
By their numbers in this assay, from the lowest: compound 1; then compound 2; then compound 3.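

In this assay, the step of a number 50 percentage points higher from compound 2 to compound 3 (beyond the scatter) shows that the linking amino group on the carbonyl carbon matters far more to the read-out than the chloro group did in the earlier step. With the aryl ring and its trifluoromethyl group kept, removing that one link leaves a much weaker effect at the concentration tested. Going a number 64.9 percentage points higher from compound 1 to compound 3 (beyond the scatter) adds the chloro change to the same replacement and gives the largest gap in the set, but nothing measured here explains why the linking group counts for so much.

A methylamino or methylene link on the same carbonyl carbon could test whether the amino hydrogen or the linking atom itself matters. On these data alone, whether a chloro group still strengthens the effect without the amino link also remains open.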